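Indole vinyl sulfones and dinitriles: growth inhibition notes

The source may report more compounds than this note shows. Statements on the series, on what has been measured and on what is new or still open speak of the compounds shown alone.

Measured so far:
compound 1 `O=C(/C(=C\c1c(-c2ccccc2)[nH]c2ccccc12)S(=O)(=O)c1ccccc1)c1ccccc1` — 8600 nM
compound 2 `COc1ccc2[nH]c(-c3ccccc3)c(C=C(C#N)C#N)c2c1` — 3500 nM

In a functional assay on U-251 cells (Homo sapiens) for inhibition, read by sulforhodamine B assay, with a stated time of 48 h (on this read-out higher numbers stand for weaker inhibition of growth and lower numbers for stronger inhibition of growth), compound 1 gives the highest of the two numbers; compound 2 sits at a lower number, a gap beyond the scatter. Among the measured compounds shown here, no pair differing in one place has been measured, so no step size is known. Compound 3 `N#C/C(=C\c1c(-c2ccccc2)[nH]c2ccccc12)S(=O)(=O)c1ccccc1` is the next case: its difference from compound 1 is cyano in place of benzoyl on a double-bonded chain carbon bound to a double-bonded chain carbon and a sulfonyl sulfur. For the measured compounds named here, only the step from compound 1 to compound 3 is expected to be small, toward a lower number, near the edge of the scatter: a 1.7-fold lower number from compound 1 to compound 3 (0.24 log units; within the scatter). Compound 3 is expected to give 5000 nM, within 1500 nM to 15000 nM.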

Compound 3, concentration for 50% growth inhibition: 2600 nM
Compound 3: middle estimate off by 1.9-fold (0.28 log units), on the high side; low and high end bracket the measured number.
By their numbers in this assay, from the lowest: compounds 3 and 2 (each within the scatter of the next); then compound 1.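

In this assay, the first step within the series is a 3.3-fold lower number from compound 1 to compound 3 (0.52 log units; beyond the scatter), with cyano in place of benzoyl on a double-bonded chain carbon bound to a double-bonded chain carbon and a sulfonyl sulfur. Growth inhibition at this position therefore depends on the group carried there, and the benzoyl ring is not required for it. No measured evidence accounts for this step. Going by these compounds, whether a carboxylic acid or a methyl ester at this position would move the number further, and in which direction, remains open. A single step also cannot show whether the size of the entering group or its identity matters more.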